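Bis-ester phenols: removing a chloro substituent

The compounds below may be only part of what the source reports. "The series", "measured", "known", "first", "only" and "open" are said of these compounds alone.

Two bis-ester phenols have been measured in a functional assay on NCI-H1299 cells (Homo sapiens) for inhibition, read by scintillation counting, with a stated time of 30 min, tested at 30 uM; a lower number here means less inhibition, a higher number more inhibition at the concentration tested (going by the name of the read-out). Compound 1 `O=C(Oc1cccc(F)c1OC(=O)c1ccccc1O)c1ccccc1O` gives 51%. Compound 2 `O=C(Oc1ccc(Cl)cc1OC(=O)c1ccc(O)cc1)c1ccc(O)cc1` gives 79%, the higher of the two numbers, and the number for compound 1 lies below it by more than the usual scatter. Compound 3 `O=C(Oc1ccccc1OC(=O)c1ccc(O)cc1)c1ccc(O)cc1` has not yet been measured; it differs from compound 2 in one place (hydrogen in place of chloro on an aromatic carbon). Among the measured compounds shown here, no pair of measured compounds differs in only one place, so there is no measured step to lean on. The account expects a modest fall in inhibition, a step of a number 14 percentage points lower from compound 2 to compound 3 (beyond the scatter) that may or may not exceed the scatter. For compound 3 the estimate is therefore 65%, with a range from 40% to 85%, resting only on the two values shown and on the small size of the change.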

Compound 3, a percentage reported as inhibition, at one concentration (the size of the read-out at that concentration, not a potency): 57.5%
Compound 3: middle estimate off by 7.5 percentage points, on the high side, within the range that was stated.
By their numbers in this assay, from the lowest: compounds 1 and 3 (each within the scatter of the next); then compound 2.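

In this assay, the chloro group on this aromatic carbon, meta to a large group and para to a large group, proves to matter: replacing it with hydrogen gives a number 21.5 percentage points lower from compound 2 to compound 3 (beyond the scatter) and leaves the rest of the structure unchanged. Among the compounds shown here, this is the first comparison that isolates a single place, so the contribution of the chloro group can now be read directly instead of being inferred from compounds that differ in several ways. Nothing available explains the size or direction of this step.

From the compounds shown here alone, only chloro and hydrogen are compared at this position, so it remains open whether a bromo, methyl or methoxy group, or an amine, would retain the higher inhibition seen with chloro. Going by these compounds, whether chloro would have a similar effect on another carbon of the same ring also remains unknown.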